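The compounds below may be only part of what the source reports. "The series", "measured", "known", "first", "only" and "open" are said of these compounds alone.

Measured compounds:
compound 1, `CC1CCN(C2CCN(S(=O)(=O)c3ccc(C(C)(C)C)cc3)CC2)CC1`, > 5000 nM
compound 2, `COc1ccccc1-c1ccc(S(=O)(=O)N2CCC(N3CCC(C)CC3)CC2)cc1`, 26 nM
compound 3, `COC(=O)c1ccc(S(=O)(=O)N2CCC(N3CCC(C)CC3)CC2)cc1`, > 5000 nM

In a functional assay on DLD-1 cells (Homo sapiens) for antiproliferative activity, read by CellTiter-Glo, with a stated time of 72 h (a lower number here means a stronger inhibitor, a higher number a weaker inhibitor), compound 3 reaches only the limit of > 5000 nM, which is a limit and not a number. Compound 1 sits at the same limit, > 5000 nM. Compound 2 stands apart with 26 nM. The steps among these three compounds are dominated by the group on the aromatic carbon of the shared core: an at least 190-fold lower number from compound 1 to compound 2 (2.28 log units; beyond the scatter), and an at least 190-fold higher number from compound 2 to compound 3 (2.28 log units; beyond the scatter), while a step that the two limits leave unreadable from compound 1 to compound 3. Two of the three values sit at the limit, (the limit of > 5000 nM in this assay, at which 2 of the 3 values shown sit).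

Compound 4, `CCCCOc1ccc(S(=O)(=O)N2CCC(N3CCC(C)CC3)CC2)cc1`, has not been measured in this assay. It differs from compound 3 in one place: butoxy in place of methoxycarbonyl on an aromatic carbon. Going by the values given here, no measured step involves butoxy, so the bearing steps are indirect. Compound 1 and compound 3, both carrying a group without a ring at that position, reach only the limit, and only compound 2, with 2-methoxyphenyl, gives a number. Compound 4 also carries a group without a ring there, so compound 4 is expected to give 4000 nM, within 500 nM to 20000 nM, most likely again as a limit. The step from compound 3 is thus expected to be an at least 1.2-fold lower number from compound 3 to compound 4 (0.09 log units; that floor lies within the scatter).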

Compound 4, half-maximal inhibitory concentration: 2300 nM
For compound 4 the middle estimate is 1.7-fold (0.24 log units) above the measured one; low and high end bracket the measured number.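

Until now, in this assay, only the 2-methoxyphenyl group of compound 2 gave a number at this position, an aromatic carbon para to a large group, and butoxy shows that a group without a ring can also bring the value off the limit: an at least 2.1-fold lower number from compound 3 to compound 4 (0.33 log units; beyond the scatter), and an at least 2.1-fold lower number from compound 1 to compound 4 (0.33 log units; beyond the scatter). Compound 1 and compound 3 remain limits and not numbers, so these two steps give only the smallest possible size of the change: the limit of > 5000 nM in this assay, at which 2 of the 4 values shown sit. Even so, butoxy does not come close to the ring-bearing group, with an 88-fold higher number from compound 2 to compound 4 (1.95 log units; beyond the scatter), so 2-methoxyphenyl remains far ahead of butoxy at this position in this assay.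

The compounds shown leave open whether the gain with butoxy comes from the carbon chain or from the oxygen that joins it to the aromatic ring, and a plain pentyl chain or a shorter methoxy group would help to separate those two readings. They also leave open whether the advantage of 2-methoxyphenyl rests on its ring or on its methoxy group, a question that an unsubstituted phenyl or a cyclohexyl group at this position would address.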